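A few compounds are considered here, and "the series" means these few. Any claim that something is new, unique, unknown or untested is made for them only; others in the source may bear on it.

Compound 3, `CCN(C(=O)C1CCN(S(=O)(=O)c2ccc3[nH]ncc3c2)CC1)[C@H](C)c1ccccc1`, gives 86% in a functional assay on CHO cells for positive allosteric modulation of muscarinic acetylcholine receptor M5 (Homo sapiens), read by calcium flux; on this read-out lower numbers stand for smaller maximal responses and higher numbers for larger maximal responses. Among the three measured compounds it holds the lowest number: compound 1, `CCN(C(=O)C1CCN(S(=O)(=O)c2ccc3c(c2)CCO3)CC1)[C@H](C)c1ccccc1`, gives 88%, and compound 2, `CCN(C(=O)C1CCN(S(=O)(=O)c2ccc3c(c2)CCC3)CC1)[C@H](C)c1ccccc1`, gives 97%. The step of a number 11 percentage points lower from compound 2 to compound 3 (beyond the scatter) is the only one of the three to lie beyond the scatter, while a number 2 percentage points lower from compound 1 to compound 3 (within the scatter) and a number 9 percentage points higher from compound 1 to compound 2 (within the scatter) both stay within it.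

Compound 4, `CCN(Cc1ccccc1C(F)(F)F)C(=O)C1CCN(S(=O)(=O)c2ccc3[nH]ncc3c2)CC1`, keeps the sulfonyl part of compound 3 and changes the other end: 2-(trifluoromethyl)benzyl in place of 1-phenylethyl on an amide-type nitrogen. Going by the values given here, none of the measured steps touches this position; all three alter the group on the sulfonyl sulfur, so there is no direct precedent for a change on the amide-type nitrogen. With the sulfonyl part of compound 3 retained, the maximal response is expected to stay near that of compound 3, and the step of a number 4 percentage points lower from compound 3 to compound 4 (within the scatter) is estimated to be small in either direction. Compound 4 is therefore estimated at 82%, in the range 58% to 102%.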

Compound 4, largest response reached (reported as percent of maximum), in percent of the reference or control that the assay uses: 96%
For compound 4 the middle estimate is 14 percentage points below the measured one, within the range that was stated.
By their numbers in this assay, from the lowest: compounds 3, 1, 4 and 2 (each within the scatter of the next, the first and the last beyond it).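

In this assay, going by these compounds alone, the change on the amide-type nitrogen gives a number 10 percentage points higher from compound 3 to compound 4 (within the scatter), so this position has now been probed for the first time, and with the sulfonyl part held constant, the two groups cannot be told apart on this read-out. The entering 2-(trifluoromethyl)benzyl has more heavy atoms than 1-phenylethyl and brings no defined stereocentre, yet neither difference shows up as a step beyond the scatter. Nothing available here bears on why the maximal response holds across this change.

The compounds shown leave open how an unsubstituted benzyl, or a benzyl carrying a carboxylic acid or an amine, would fare on this nitrogen. They also leave open whether 2-(trifluoromethyl)benzyl would give the same picture with 2,3-dihydro-1H-inden-5-yl on the sulfonyl sulfur.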